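Aryl Swap in a Weakly Cytotoxic Compound Series

A few compounds are considered here, and "the series" means these few. Any claim that something is new, unique, unknown or untested is made for them only; others in the source may bear on it.

The compounds in this set are tested in a functional assay on NCI-H1975 cells (Homo sapiens) for cytotoxicity, read by CCK-8 assay, with a stated time of 72 h; a higher number here means a weaker inhibitor, a lower number a stronger inhibitor. Compound 1 `C=CCn1c(=O)/c(=C\c2ccc(Cl)c(Cl)c2)[nH]c(=O)/c1=C\c1ccccc1` is reported in this assay as "not active" (no number reported), with no single number given. Compound 2 `C=CCn1c(=O)/c(=C\c2cc(F)ccc2C)[nH]c(=O)/c1=C\c1ccccc1OC` gives 7300 nM in this assay, and that is the only number among the entries shown, so compound 2 stands alone, with nothing measured to rank it against. Compound 3 `C=CCn1c(=O)/c(=C\c2ccc(C)cc2)[nH]c(=O)/c1=C\c1ccccc1OC` has not been tested. It differs from compound 2 in one place: 4-methylphenyl in place of 5-fluoro-2-methylphenyl on a double-bonded chain carbon bound to an aromatic carbon. Going by the values given here, no step between two measured compounds is available to gauge a change of this kind, so the expectation rests on compound 2 alone. The step of a 1.2-fold higher number from compound 2 to compound 3 (0.09 log units; within the scatter) is expected to be modest, either within the scatter or leaning slightly toward weaker inhibition. Compound 3 is therefore estimated at 9000 nM in this assay, within a range from 3000 nM to 30000 nM.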

Compound 3, half-maximal inhibitory concentration: "not active" (no number reported)
Compound 3: no number reported, and the estimate cannot be compared.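

Going by these compounds alone, compound 3 is reported without a number in this assay, so no step from compound 2 to compound 3 can be read. No measurement shown bears on this result. The compounds shown leave open how 4-methylphenyl and 5-fluoro-2-methylphenyl compare numerically on the shared core.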